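The source may report more compounds than this note shows. Statements on the series, on what has been measured and on what is new or still open speak of the compounds shown alone.

The study concerns a small set of compounds tested in a functional assay on the whole organism for inhibition, with Rattus norvegicus as the target, with stated times of 1 h and 3.5 h, at a dose of 100 mg/kg by the oral route; a lower number here means less inhibition, a higher number more inhibition at the dose given (going by the name of the read-out). Compound 1, with the structure `Nc1nccc(-c2ccccn2)n1`, gives 17% in this assay. Compound 2, with the structure `CCOC(=O)Nc1ncc(-c2ccccc2)c(C(C)(C)C)n1`, gives 24%. Compound 3, with the structure `CC(C)(C)c1ccnc(N)n1`, gives 32%.

Compound 3 stands clear of compound 1, a gap that lies beyond the scatter of repeated measurements, so compound 3 inhibits more than compound 1 at the dose given. Its gap to compound 2, on the other hand, lies within the scatter, so these two cannot be told apart on the numbers at hand.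

Compound 4, with the structure `CC(C)(C)c1ccnc(S)n1`, has not yet been measured. It differs from compound 3 in one place: sulfanyl in place of amino on an aromatic carbon. Both groups are small, each carrying one donor and one acceptor, and both sit on the same carbon of the same ring. Among the measured compounds shown here, no pair of measured compounds shows what such a swap does in this assay, so nothing here points to a large shift in either direction. The step from compound 3 to compound 4 is therefore expected to be small, a number 5 percentage points lower from compound 3 to compound 4 (within the scatter), and likely to fall within the scatter. On that basis compound 4 is estimated to give 27% in this assay, with a range from 12% to 42%.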

Compound 4, a percentage reported as inhibition, in the whole organism at one dose (the size of the read-out at that dose, not a potency): 22%
Beside the measured number, compound 4's estimate is 5 percentage points above it, within the range that was stated.
By their numbers in this assay, from the lowest: compounds 1, 4, 2 and 3 (each within the scatter of the next, the first and the last beyond it).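

Sulfanyl in place of amino, on an aromatic carbon between two ring nitrogen atoms, is the first change in this set that can be read in one place, and in this assay it gives a number 10 percentage points lower from compound 3 to compound 4 (within the scatter). That step stays within the scatter, so compound 3 and compound 4 cannot be told apart, and this swap of one heavy atom, nitrogen for sulfur, shows no clear effect on the read-out at this position. Nothing measured here explains the result or shows what the swap does beyond this one pair.

Still open, as far as these compounds go, is whether hydroxyl, methoxy or a longer chain such as propylamino on the same aromatic carbon would move the read-out beyond the scatter from compound 3. Also open, from the compounds shown here alone, is whether sulfanyl in place of amino would give a similar step on a core that also carries the phenyl group seen in compound 2, since a single pair on a single core cannot show how far this finding extends.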